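Chain extension on the acylamide series, next step

The source may report more compounds than this note shows. Statements on the series, on what has been measured and on what is new or still open speak of the compounds shown alone.

Among the compounds with values here, compound 3 `CCCCCCCCCCCCCCCC(=O)Nc1ccn([C@@H]2CO[C@H](CO)O2)c(=O)n1` gives 20 nM in a functional assay on SW1573 cells (Homo sapiens) for cytotoxicity, read by sulforhodamine B assay, with a stated time of 72 h (on this read-out lower numbers stand for stronger inhibition and higher numbers for weaker inhibition), the low end of the three numbers so far, though not separated from compound 2 `CCCCCCCCCCCC(=O)Nc1ccn([C@@H]2CO[C@H](CO)O2)c(=O)n1`, which gives 30 nM within the scatter of it; compound 1 `CCCCCCCCC(=O)Nc1ccn([C@@H]2CO[C@H](CO)O2)c(=O)n1` gives 276 nM. Compound 4 `CCCCCCCCCCCCCCCCCC(=O)Nc1ccn([C@@H]2CO[C@H](CO)O2)c(=O)n1` differs from compound 3 by ethyl in place of hydrogen on a saturated chain carbon, ten or more bonds along the chain from a carbonyl carbon. The earlier lengthenings were clearly productive, a 9.2-fold lower number from compound 1 to compound 2 (0.96 log units; beyond the scatter) and a 14-fold lower number from compound 1 to compound 3 (1.14 log units; beyond the scatter), but the step most like the present one, a 1.5-fold lower number from compound 2 to compound 3 (0.18 log units; within the scatter), stayed within the scatter, so the gain from adding chain appears to have levelled off between compound 2 and compound 3. For compound 4 no step beyond the scatter is therefore expected in this assay, the expected step being no change at the digits printed from compound 3 to compound 4 (within the scatter). Compound 4 is estimated at 20 nM, range 8 nM to 50 nM.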

Compound 4, half-maximal inhibitory concentration: 125 nM
The estimate for compound 4 lay 6.3-fold (0.80 log units) below the measured number; the whole stated range lies below it.
By their numbers in this assay, from the lowest: compounds 3 and 2 (each within the scatter of the next); then compound 4; then compound 1.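

In this assay, the response to chain length at this position turns over rather than staying flat: ethyl in place of hydrogen gives a 6.3-fold higher number from compound 3 to compound 4 (0.80 log units; beyond the scatter). The loss also holds against a shorter chain, a 4.2-fold higher number from compound 2 to compound 4 (0.62 log units; beyond the scatter), while a gain over the shortest chain remains, a 2.2-fold lower number from compound 1 to compound 4 (0.34 log units; beyond the scatter). Nothing available accounts for this reversal. Still open, going by these compounds, is whether a longer chain would continue the rise, and whether a terminal amine or carboxylic acid on the chain would shift the number.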